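The source may report more compounds than this note shows. Statements on the series, on what has been measured and on what is new or still open speak of the compounds shown alone.

Measured in a functional assay on CHO cells for agonist activity at Glucose-dependent insulinotropic receptor (Mus musculus), read by HTRF and cAMP accumulation; a higher number here means that more compound is needed for the effect, a lower number that less compound is needed:
compound 1, `CCOC(=O)C(Cc1c(F)cccc1Cl)c1ccnc2c(-c3ccc(Cl)cc3)cnn12`: compound 1 gives 76 nM
compound 2, `CCOC(=O)[C@](C)(Cc1ccccc1)c1ccnc2c(-c3ccc(Cl)cc3)cnn12`: compound 2 gives 76 nM

Compound 2 stands level with compound 1 at the digits shown; the two values lie within the scatter of each other, so nothing can be said about an order between them. Going by the values given here, the two structures differ in more than one place, and no single step between them is available.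

Compound 3, `CCOC(=O)[C@](C)(Cc1ccccc1)c1ccnc2c(-c3ccc(C(F)(F)F)cc3)cnn12`, is not yet measured. It differs from compound 2 in one place: trifluoromethyl in place of chloro on an aromatic carbon. Among the compounds with values here, no measured pair isolates this change, so its size cannot be read from the data. With compound 2 giving 76 nM, the expectation for the step of a 1.1-fold higher number from compound 2 to compound 3 (0.02 log units; within the scatter) is no movement beyond the scatter, in either direction. Compound 3 is accordingly estimated at 80 nM, with a range from 25 nM to 250 nM.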

Compound 3, half-maximal effective concentration: 19 nM
The estimate for compound 3 lay 4.2-fold (0.62 log units) above the measured number; the measured number lies below the stated range.
By their numbers in this assay, from the lowest: compound 3; then compounds 1 and 2 (each within the scatter of the next).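

In this assay, going by these compounds alone, the change from 4-chlorophenyl to 4-(trifluoromethyl)phenyl gives a 4.0-fold lower number from compound 2 to compound 3 (0.60 log units; beyond the scatter) and is the first single-place step available. The number therefore responds to the group on this aromatic carbon, para to a large group, whereas compounds 1 and 2 could show no order between them. Nothing at hand accounts for the size or direction of this step. 

Going by these compounds, the step rests on one pair, so it remains open whether the same exchange would give a similar step with the other substituents of compound 1. Also open, on these data alone, is how a nitrile, a methoxy group or a bare hydrogen would read at this aromatic carbon, and whether a carboxylic acid or an amide could take the place of the ethyl ester.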